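This account rests on a few compounds, and the source may have more. Where it says the series, first, only, none or still open, it means among the compounds named here.

For the measured compounds named here, compound 1 `Cc1ccc2nc(NC(=O)CNC(=O)c3nn(-c4ccccc4)c(=O)c4ccccc34)sc2c1` is the first of three measured compounds in this set. In an assay on L cells for inhibition of Protein-serine O-palmitoleoyltransferase porcupine (Mus musculus), read by reporter gene assay, with a stated time of 24 h (on this read-out higher numbers stand for an effect only at larger amounts of compound and lower numbers for an effect already at smaller amounts), compound 1 gives 35 nM. Compound 2 `COc1ccc(-n2nc(C(=O)NCC(=O)Nc3nc4ccc(C)cc4s3)c3ccccc3c2=O)cc1` differs from it in one place, (methoxy in place of hydrogen on an aromatic carbon), and in this assay compound 2 gives 25 nM; the step of a 1.4-fold lower number from compound 1 to compound 2 (0.15 log units; within the scatter) stays within the scatter of repeated measurements. Compound 3 `COc1ccc2nc(NC(=O)CSc3nc4c(c(=O)n3-c3ccccc3)SCC4)sc2c1` rests on a different core, and the difference between the two cores is not broken down here. In this assay compound 3 gives 40 nM, which lies within the scatter of both compound 1 and compound 2, so no order among the three can be read from these numbers.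

Compound 4 `COc1ccc2nc(NC(=O)CSc3nc4c(c(=O)n3-c3ccccc3OC)SCC4)sc2c1` has not yet been measured. It is made from compound 3 by the same kind of change, (methoxy in place of hydrogen on an aromatic carbon), though here the methoxy sits ortho to a large group rather than para to a large group as in compound 2. Going by the values given here, because the one measured instance of this change, a 1.4-fold lower number from compound 1 to compound 2 (0.15 log units; within the scatter), stayed within the scatter, compound 4 is expected to show a step of a 1.1-fold lower number from compound 3 to compound 4 (0.06 log units; within the scatter) of similar size. Compound 4 is therefore estimated at 35 nM in this assay, with a range from 15 nM to 90 nM.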

Compound 4, half-maximal effective concentration: 50 nM
Compound 4: middle estimate off by 1.4-fold (0.15 log units), on the low side; the range from low to high includes it.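

On the second core, methoxy in place of hydrogen on an aromatic carbon gives a 1.3-fold higher number from compound 3 to compound 4 (0.10 log units; within the scatter) in this assay. Set beside the earlier step on the core of compound 1, this step cannot be told apart from it: the same change on two cores in this assay, a 1.4-fold lower number (0.15 log units; within the scatter) from compound 1 to compound 2 and a 1.3-fold higher number (0.10 log units; within the scatter) from compound 3 to compound 4, 1.8-fold (0.24 log units) apart, within the scatter of two such steps. The change can therefore be carried between these two cores without a step that rises above the scatter, but two pairs do not show that it acts alike on both cores, or that it has any real effect on either, and the methoxy also sits at a different place in each pair, so core and position cannot be separated.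

The compounds shown leave open whether another group at this place, such as a hydroxyl, a carboxylic acid or an amine, or a longer chain such as ethoxy, would give a step beyond the scatter. They also leave open how the change from phenyl to 2-methoxyphenyl would read on the core of compound 1.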